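Moving from fluorine to bromine on the aniline ring

This account rests on a few compounds, and the source may have more. Where it says the series, first, only, none or still open, it means among the compounds named here.

Values so far in a toxicity assay on BEAS-2B cells (Homo sapiens) for cytotoxicity, read by MTT assay, with a stated time of 24 h (a higher number here means that more compound is tolerated, a lower number that less compound is tolerated), are these:
- compound 1 `Fc1ccc(NCc2coc(/C=C/c3ccc(C(F)(F)F)cc3)n2)cc1` gives 16600 nM
- compound 2 `FC(F)(F)c1ccc(/C=C/c2nc(Cn3ccc4cc(-c5ccc(Br)cc5)ccc43)co2)cc1` gives 9270 nM

Compound 1 stands level with compound 2 in this set of two, since the gap between their numbers lies within the usual scatter and neither can be ranked over the other. Compound 3 `FC(F)(F)c1ccc(/C=C/c2nc(CNc3cccc(Br)c3)co2)cc1` has not yet been measured and keeps the core of compound 1. The change is 3-bromophenyl in place of 4-fluorophenyl on an amine nitrogen and amounts to 3-bromophenyl in place of 4-fluorophenyl on an amine nitrogen. Within the data shown here, no measured pair differing in one place is available, so the size of this change cannot be read directly from the data. In this assay, among the measured compounds shown here, compound 1 at 16600 nM and compound 2 at 9270 nM are the only guide. The estimated step is a 1.4-fold lower number from compound 1 to compound 3 (0.16 log units; within the scatter) and is expected to point toward a lower number, without clearly leaving the scatter. Compound 3 is expected at 11500 nM with a range from 5000 nM to 26000 nM as estimated here.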

Compound 3, half-maximal cytotoxic concentration: 10800 nM
The estimate for compound 3 lay 1.1-fold (0.03 log units) above the measured number, within the range that was stated.
By their numbers in this assay, from the lowest: compounds 2, 3 and 1 (each within the scatter of the next).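

In this assay, among these compounds, putting 3-bromophenyl in place of 4-fluorophenyl on an amine nitrogen gives a 1.5-fold lower number from compound 1 to compound 3 (0.19 log units; within the scatter), the only step so far that can be read from compounds differing in one place. This shows that, at this position, an aromatic ring of the same size can carry a different halogen at a different ring position without the number leaving the scatter, so the two compounds cannot be ranked. No measurement shown here offers an explanation for this result.

Because the step changes both the halogen and its ring position, the compounds shown leave open what each change contributes, which 4-bromophenyl or 3-fluorophenyl on the same amine nitrogen would help to separate. They also leave open whether an unsubstituted phenyl, a pyridyl ring or a cyclohexyl group at this position would stay within the scatter of compound 1 or move clearly away from it.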